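A few compounds are considered here, and "the series" means these few. Any claim that something is new, unique, unknown or untested is made for them only; others in the source may bear on it.

Measured so far in a functional assay on A549 cells (Homo sapiens) for inhibition, read by sulforhodamine B assay, tested at 100 uM; a lower number here means less inhibition of growth, a higher number more inhibition of growth at the concentration tested:
compound 1 `COc1cc(C2CC(c3ccc(OCc4cn(Cc5ccc([N+](=O)[O-])cc5)nn4)cc3)=NN2C(C)=O)ccc1Oc1cn(Cc2ccc([N+](=O)[O-])cc2)nn1`: 42%
compound 2 `COc1ccc(C2CC(c3ccc(OCc4cn(Cc5ccc([N+](=O)[O-])cc5)nn4)cc3)=NN2C(C)=O)cc1`: 33%
compound 3 `COc1cc(C2CC(c3ccc(Br)cc3)=NN2C(C)=O)ccc1OCc1cn(Cc2ccc([N+](=O)[O-])cc2)nn1`: 17%

Compound 3 stands lowest of the three numbers; compound 2 sits higher by a gap beyond the scatter, and compound 1 sits higher still, also beyond the scatter. Compound 4 `COc1ccc(C2=NN(C(C)=O)C(c3ccc(OCc4cn(Cc5ccc([N+](=O)[O-])cc5)nn4)c(OC)c3)C2)cc1` differs from compound 3 by methoxy in place of bromo on an aromatic carbon. For the measured compounds named here, no measured pair isolates this change. Going by the values given here, compound 2, which also carries a 4-methoxyphenyl, and compound 3 differ in more than one place, so their two values show only that the methoxy-bearing compound gives the higher number. A modest upward step is expected, a number 11 percentage points higher from compound 3 to compound 4 (beyond the scatter). Compound 4 is estimated at 28%, within 14% to 42%.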

Compound 4, percent growth inhibition at one concentration: 84%
For compound 4 the middle estimate is 56 percentage points below the measured one; the measured number lies above the stated range.
By their numbers in this assay, from the lowest: compound 3; then compounds 2 and 1 (each within the scatter of the next); then compound 4.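

In this assay, for the compounds shown here, the change from 4-bromophenyl to 4-methoxyphenyl gives a number 67 percentage points higher from compound 3 to compound 4 (beyond the scatter) and is the first step that isolates a single place. On this aromatic carbon, para to a large group, replacing bromo with methoxy is enough on its own to produce a large change, which compound 2 and compound 3, differing in more than one place, could not show. No available data bear on the reason for this step.

Going by these compounds, whether a hydroxyl, an amine or a longer alkoxy chain at this position would give a similar number remains open. Also open, on these data alone, is whether the same step would appear on the core of compound 1.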